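This account rests on a few compounds, and the source may have more. Where it says the series, first, only, none or still open, it means among the compounds named here.

Series notes; numbers in an assay on microsomes from liver for inhibition of 3-hydroxy-3-methylglutaryl-coenzyme A reductase (Rattus norvegicus); on this read-out higher numbers stand for weaker inhibition and lower numbers for stronger inhibition:
compound 1, `CC(C)c1c(C(=O)N2CCCC2c2ccccc2)nn(-c2ccc(F)cc2)c1OC[C@@H](O)C[C@@H](O)CC(=O)O`, gives 14 nM.
compound 2, `COCc1cccc(CNC(=O)c2nn(-c3ccc(F)cc3)c(OC[C@@H](O)C[C@@H](O)CC(=O)O)c2C(C)C)c1`, gives 31 nM.

Among the measured compounds shown here, compound 2 carries the higher of the two numbers in this assay; the only measured step, a 2.2-fold higher number from compound 1 to compound 2 (0.35 log units; beyond the scatter), separates it from compound 1, and it lies beyond the scatter. Compound 3, `CC(C)c1c(C(=O)N(C)Cc2ccc(F)cc2)nn(-c2ccc(F)cc2)c1OC[C@@H](O)C[C@@H](O)CC(=O)O`, is not yet measured. It differs from compound 2 as follows: (4-fluorobenzyl)(methyl)amino in place of (3-(methoxymethyl)benzyl)amino on a carbonyl carbon.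

For the measured compounds named here, the one measured step bears on this change only loosely: it also exchanged the group on the carbonyl carbon, and compound 1 with 2-phenylpyrrolidin-1-yl gave the lower number. Two compounds give no pattern, so the step to compound 3 is expected to be small, toward a slightly lower number, and within the scatter: a 1.4-fold lower number from compound 2 to compound 3 (0.15 log units; within the scatter). Compound 3 is therefore expected to give about 22 nM in this assay, with a range from 8 nM to 60 nM.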

Compound 3, half-maximal inhibitory concentration: 18 nM
Compound 3: middle estimate off by 1.2-fold (0.09 log units), on the high side; low and high end bracket the measured number.
By their numbers in this assay, from the lowest: compounds 1, 3 and 2 (each within the scatter of the next, the first and the last beyond it).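

In this assay, the exchange on the carbonyl carbon gives a 1.7-fold lower number from compound 2 to compound 3 (0.24 log units; within the scatter), so the hydrogen-bond donor and acceptor counted on (3-(methoxymethyl)benzyl)amino are absent from (4-fluorobenzyl)(methyl)amino without a step beyond the scatter. The open-chain (4-fluorobenzyl)(methyl)amino also stands close to the ring-containing amide of compound 1, with a 1.3-fold higher number from compound 1 to compound 3 (0.11 log units; within the scatter), so 2-phenylpyrrolidin-1-yl is not set apart from it here. Compound 3 thus lies within the scatter of both earlier compounds, although those two lie beyond the scatter of each other.

The step from compound 2 to compound 3 changes the methyl on the amide nitrogen and the ring substituent together, and (4-fluorobenzyl)amino would separate the two. How a group without an aromatic ring, such as dimethylamino, behaves on this carbonyl carbon remains open, and the data give no explanation for any of these steps.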